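Chloro in Place of Nitro on the Shared Core

The source may report more compounds than this note shows. Statements on the series, on what has been measured and on what is new or still open speak of the compounds shown alone.

Compound 1 `Cc1noc(-c2cc3cc(Cl)ccc3[nH]2)n1`: in a functional assay on MIA PaCa-2 cells (Homo sapiens) for antiproliferative activity, read by WST assay, with a stated time of 72 h (a lower number here means a stronger inhibitor, a higher number a weaker inhibitor), compound 1 gives > 50000 nM, which is a limit of the assay and not a number.
Compound 2 `Clc1ccc2[nH]c(-c3nc(-c4ccccc4)no3)cc2c1`: in this assay compound 2 gives 23100 nM.
Compound 3 `O=[N+]([O-])c1ccc2[nH]c(-c3nc(-c4ccc(Cl)cc4)no3)cc2c1`: in this assay compound 3 gives 17600 nM.

Compound 3 holds the lowest of the two numbers shown, but compound 2 sits within the usual scatter of it, so the two cannot be placed in order. Compound 1 stands at the limit of > 50000 nM in this assay, at which 1 of the 3 values shown sits. Among the measured compounds shown here, the only measured step, an at least 2.1-fold lower number from compound 1 to compound 2 (0.33 log units; beyond the scatter), concerns a change at a different part of the shared core and offers no guide to the change considered here.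

Compound 4 `Clc1ccc(-c2noc(-c3cc4cc(Cl)ccc4[nH]3)n2)cc1` differs from compound 3 by chloro in place of nitro on an aromatic carbon. For the measured compounds named here, no measured pair shows what this exchange does in this assay. With nothing to point either way, the expectation is a step within the scatter, a 1.0-fold lower number from compound 3 to compound 4 (0.02 log units; within the scatter). Compound 4 is therefore estimated at 17000 nM in this assay, with a range from 6000 nM to 50000 nM.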

Compound 4, half-maximal inhibitory concentration: > 50000 nM
Compound 4 ended at the assay's limit; the forecaster's own chance of this, stated with the estimate: 15%; middle value at least 2.9-fold (0.46 log units) from the limit.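

Chloro in place of nitro on this aromatic carbon of the shared core is not a neutral exchange in this assay: it gives an at least 2.8-fold higher number from compound 3 to compound 4 (0.45 log units; beyond the scatter) and is the first measured sign that this position responds to what sits on it. Chloro in place of hydrogen on an aromatic carbon also brings no gain, giving an at least 2.1-fold higher number from compound 2 to compound 4 (0.33 log units; beyond the scatter) as the second step into compound 4. Compound 4 stands at a limit of the assay, so both step sizes are minimums and the step from compound 1 to compound 4 cannot be read: (the limit of > 50000 nM in this assay, at which 2 of the 4 values shown sit).

Among the compounds shown, it remains open how an amine or a carboxylic acid on this carbon would compare with nitro. Also open, as far as these compounds go, is whether nitro would give a similar number with phenyl in place of 4-chlorophenyl.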